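The source may hold more compounds than are shown below. What is called first, only, known or untested is meant among the compounds shown, and "the series" means these compounds.

Compound 1 `N/C(=N\NC(=S)N1CCCCCC1)c1ccccn1` and compound 2 `N/C(=N\NC(=S)N1CCCCC1)c1ccccn1` share the same thiosemicarbazide arm on the pyridine-bearing amidine; the difference between their two cores is not broken down here. In a functional assay on A-431 cells (Homo sapiens) for cytotoxicity, read by MTT assay, with a stated time of 72 h, tested at 10 uM (on this read-out lower numbers stand for less inhibition of growth and higher numbers for more inhibition of growth at the one concentration tested), compound 1 gives 67%, and compound 2 gives 68.1%, within the scatter of each other. Compound 3 `Cc1cccc(/C(N)=N/NC(=S)N2CCCCCC2)n1` carries the change (methyl in place of hydrogen on an aromatic carbon); in this assay compound 3 gives 45.8%, and the step of a number 21.2 percentage points lower from compound 1 to compound 3 (beyond the scatter) is modest. Compound 4 `Cc1ccnc(/C(N)=N/NC(=S)N2CCCCC2)c1` carries the change methyl in place of hydrogen on an aromatic carbon: the same kind of change, but here the methyl sits meta to a large group and opposite the ring nitrogen rather than next to the ring nitrogen. Going by the values given here, because the only measured instance is a number 21.2 percentage points lower from compound 1 to compound 3 (beyond the scatter), a step of similar size is expected, a number 16.1 percentage points lower from compound 2 to compound 4 (beyond the scatter), though the different place adds uncertainty. Compound 4 is therefore estimated at 52%, ranging from 35% to 70%.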

Compound 4, percent growth inhibition at one concentration: 39.7%
The estimate for compound 4 lay 12.3 percentage points above the measured number; the measured number falls inside the stated range.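

In this assay the new step, a number 28.4 percentage points lower from compound 2 to compound 4 (beyond the scatter), stands beside the earlier one, and the two agree: the same change on two cores in this assay, a number 21.2 percentage points lower (beyond the scatter) from compound 1 to compound 3 and a number 28.4 percentage points lower (beyond the scatter) from compound 2 to compound 4, 7.2 percentage points apart, within the scatter of two such steps. Within these two pairs, methyl in place of hydrogen on an aromatic carbon thus carried over from one core to the other in direction and in size, although the methyl sits at a different place on the ring in each pair. This does not show that the place is without effect, as each core is seen with the methyl at one place only, and two pairs make no rule for the whole series.

The compounds shown leave open whether each core would give the same step with the methyl at the other place. They also leave open whether an ethyl, a methoxy or an amine on the ring would give a step of similar size.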